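Alpha-methyl on the bromoacetamide arm, revisited on a trimethoxyphenyl urea

The compounds below may be only part of what the source reports. "The series", "measured", "known", "first", "only" and "open" are said of these compounds alone.

Compound 1 `O=CNC(=O)Nc1cccc(NC(=O)CBr)c1` and compound 2 `CC(Br)C(=O)Nc1cccc(NC(=O)NC=O)c1` share a formyl urea core and differ only by methyl in place of hydrogen on a saturated chain carbon bound to a bromine atom and a carbonyl carbon. In a functional assay on CCRF-CEM cells (Homo sapiens) for cytotoxicity, read by MTT assay, with a stated time of 72 h (on this read-out higher numbers stand for weaker inhibition and lower numbers for stronger inhibition), compound 1 gives 850 nM, while compound 2 gives 10200 nM; the step of a 12-fold higher number from compound 1 to compound 2 (1.08 log units; beyond the scatter). Compound 3 `COc1cc(NC(=O)Nc2cccc(NC(=O)CBr)c2)cc(OC)c1OC` carries a different core; the difference between the two cores is not broken down here. In this assay compound 3 gives 1000 nM, a number that lies within the scatter of compound 1. Compound 4 `COc1cc(NC(=O)Nc2cccc(NC(=O)C(C)Br)c2)cc(OC)c1OC` differs from compound 3 by methyl in place of hydrogen on a saturated chain carbon bound to a bromine atom and a carbonyl carbon, the same change, at the same place, as from compound 1 to compound 2. Among the compounds with values here, because the single measured instance of this change, a 12-fold higher number from compound 1 to compound 2 (1.08 log units; beyond the scatter), was large, compound 4 is expected to show a step of similar size, a 12-fold higher number from compound 3 to compound 4 (1.08 log units; beyond the scatter), in this assay. Compound 4 is therefore estimated at 12000 nM, with a range from 4000 nM to 36000 nM.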

Compound 4, half-maximal inhibitory concentration: 3990 nM
Compound 4: middle estimate off by 3.0-fold (0.48 log units), on the high side; the measured number lies below the stated range.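

In this assay, methyl in place of hydrogen on the saturated chain carbon bound to a bromine atom and a carbonyl carbon again weakens the read-out, giving a 4.0-fold higher number from compound 3 to compound 4 (0.60 log units; beyond the scatter) on the core of compound 3. The direction carries over from one core to the other, but the size of the step does not: the same change on two cores in this assay, a 12-fold higher number (1.08 log units; beyond the scatter) from compound 1 to compound 2 and a 4.0-fold higher number (0.60 log units; beyond the scatter) from compound 3 to compound 4, 3.0-fold (0.48 log units) apart, beyond the scatter of two such steps. Two cores show that the size depends on the setting, yet they do not show which part of the core is responsible, and they give no rule for a third core.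

From the compounds shown here alone, it remains open whether an ethyl group in place of the methyl would weaken the read-out further. Going by these compounds, whether a chlorine atom in place of the bromine atom would leave these steps unchanged is also open.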